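A few compounds are considered here, and "the series" means these few. Any claim that something is new, unique, unknown or untested is made for them only; others in the source may bear on it.

In a functional assay on CLL cells (Homo sapiens) for cytotoxicity, read by MTT assay, with a stated time of 48 h (a lower number here means that less compound is needed, a higher number that more compound is needed for the effect), compound 1 `C=C(CC)C(=O)c1ccc(OCC(=O)Nc2ccc(C(=O)O)cn2)c(Cl)c1Cl` gives 14900 nM and compound 2 `C=C(CC)C(=O)c1ccc(OCC(=O)Nc2ccc(O)c(Cl)c2)c(Cl)c1Cl` gives 5500 nM. Among the compounds with values here, the only step measured so far is a 2.7-fold lower number from compound 1 to compound 2 (0.43 log units; beyond the scatter). Compound 2 thus stands at the lowest of the two numbers. Compound 3 `C=C(CC)C(=O)c1ccc(OCC(=O)Nc2ccc(C#N)cc2)c(Cl)c1Cl` alters the same position once more: 4-cyanophenyl in place of 3-chloro-4-hydroxyphenyl on an amide-type nitrogen. Only the modest step of a 2.7-fold lower number from compound 1 to compound 2 (0.43 log units; beyond the scatter) bears on this change, and from it a shift of comparable size is expected in this assay, more likely toward a higher number. Compound 3 is estimated at 8000 nM, within 3000 nM to 25000 nM, an expected step of a 1.5-fold higher number from compound 2 to compound 3 (0.16 log units; within the scatter).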

Compound 3, half-maximal effective concentration: 7800 nM
Compound 3: middle estimate off by 1.0-fold (0.01 log units), on the high side; the measured number falls inside the stated range.
By their numbers in this assay, from the lowest: compounds 2, 3 and 1 (each within the scatter of the next, the first and the last beyond it).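

In this assay, putting 4-cyanophenyl, which has no hydrogen-bond donor and no chlorine, on the amide-type nitrogen in place of 3-chloro-4-hydroxyphenyl gives a 1.4-fold higher number from compound 2 to compound 3 (0.15 log units; within the scatter). Set against the carboxypyridine, the same group gives a 1.9-fold lower number from compound 1 to compound 3 (0.28 log units; within the scatter), so compound 3 cannot be told apart from either of the other two, even though those two differ beyond the scatter. Nothing available explains these numbers. Still open, from the compounds shown here alone, is how a plain phenyl ring, an amine on the ring or a longer chain on this nitrogen would read.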